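Methoxy for methyl on the aryl group

The source may report more compounds than this note shows. Statements on the series, on what has been measured and on what is new or still open speak of the compounds shown alone.

In a functional assay on L1210 cells (Mus musculus) for antiproliferative activity (on this read-out lower numbers stand for stronger inhibition and higher numbers for weaker inhibition), compound 2 (`COc1cc(C(=O)c2sc(-c3ccc(C)cc3)cc2N)cc(OC)c1OC`) gives 18 nM and stands within the scatter of compound 1 (`COc1cc(C(=O)c2sc(-c3ccsc3)cc2N)cc(OC)c1OC`), which gives 12 nM in the same read-out. Compound 3 (`COc1ccc(-c2cc(N)c(C(=O)c3cc(OC)c(OC)c(OC)c3)s2)cc1`) carries methoxy in place of methyl on an aromatic carbon, para to a large group (methoxy in place of methyl on an aromatic carbon). For the measured compounds named here, the only measured step, a 1.5-fold higher number from compound 1 to compound 2 (0.18 log units; within the scatter), puts 4-methylphenyl in place of thiophen-3-yl and does not cover this exchange directly. No change beyond the scatter is therefore expected in this assay, and the expected step is a 1.2-fold lower number from compound 2 to compound 3 (0.08 log units; within the scatter) in size. Compound 3 is estimated at 15 nM (expected range 6 nM to 40 nM).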

Compound 3, half-maximal inhibitory concentration: 45 nM
For compound 3 the middle estimate is 3.0-fold (0.48 log units) below the measured one, outside the stated range (above it).
By their numbers in this assay, from the lowest: compounds 1 and 2 (each within the scatter of the next); then compound 3.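

In this assay, methoxy in place of methyl on the aromatic carbon para to a large group gives a 2.5-fold higher number from compound 2 to compound 3 (0.40 log units; beyond the scatter), so a small exchange at this position moves the number beyond the scatter. Against thiophen-3-yl, 4-methoxyphenyl gives a 3.8-fold higher number from compound 1 to compound 3 (0.57 log units; beyond the scatter), while 4-methylphenyl stayed within the scatter at a 1.5-fold higher number from compound 1 to compound 2 (0.18 log units; within the scatter). Nothing available here accounts for this difference between methoxy and methyl.

Going by these compounds, whether the rise is specific to methoxy stays open. Ethoxy, hydroxy or chlorine on the same aromatic carbon would bear on that.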